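The source may hold more compounds than are shown below. What is called first, only, known or untested is meant among the compounds shown, and "the series" means these compounds.

Of the compounds shown here, two built on the same core have been measured in a functional assay on MKN-74 cells (Homo sapiens) for inhibition, read by colorimetric assay and sulforhodamine B assay, with a stated time of 48 h; a lower number here means a stronger inhibitor of growth, a higher number a weaker inhibitor of growth. Compound 1 `CCCCCCCCCCCC[C@@H](O)[C@H]1CC[C@H]([C@H](O)CCCCCCCCCCNC(=O)c2cccs2)O1`, with thiophen-2-yl on a carbonyl carbon, gives 1510 nM. Compound 2 `CCCCCCCCCCCC[C@@H](O)[C@H]1CC[C@H]([C@H](O)CCCCCCCCCCNC(=O)c2ccco2)O1`, with furan-2-yl there instead, gives 1700 nM, so compound 2 stands level with compound 1 within the scatter, and neither can be ranked over the other. Compound 3 `CCCCCCCCCCCC[C@@H](O)[C@H]1CC[C@H]([C@H](O)CCCCCCCCCCNC(=O)c2ccoc2)O1` keeps the rest of the structure and carries furan-3-yl in place of furan-2-yl on a carbonyl carbon. The two have the same atoms, joined differently. For the measured compounds named here, only one measured step bears on this change, the exchange of thiophen-2-yl for furan-2-yl at the same place. Going by the values given here, it is indirect evidence, since no measured compound yet carries furan-3-yl. With only a 1.1-fold higher number from compound 1 to compound 2 (0.05 log units; within the scatter) to go on, no step beyond the scatter is expected in this assay. The expected change is a 1.1-fold lower number from compound 2 to compound 3 (0.03 log units; within the scatter). Compound 3 is estimated at 1600 nM, with an expected range of 800 nM to 3200 nM.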

Compound 3, concentration for 50% growth inhibition: 21900 nM
Beside the measured number, compound 3's estimate is 14-fold (1.14 log units) below it; measured number outside the range, above it.
By their numbers in this assay, from the lowest: compounds 1 and 2 (each within the scatter of the next); then compound 3.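

At this place, on a carbonyl carbon whose other neighbour is an amide-type nitrogen, this assay responds to how the five-membered ring is joined and not only to which ring is present: furan-3-yl in place of furan-2-yl brings a 13-fold higher number from compound 2 to compound 3 (1.11 log units; beyond the scatter) even though both groups have the same atoms and the same counts of hydrogen-bond donors and acceptors. Furan-3-yl in place of thiophen-2-yl brings a 15-fold higher number from compound 1 to compound 3 (1.16 log units; beyond the scatter) and so shows that the exchange of thiophen-2-yl for furan-2-yl, which stayed within the scatter, gave no measure of how much this position can change the number. Nothing available here accounts for this large step, and its origin remains unexplained.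

On these data alone, whether thiophen-3-yl would stand with thiophen-2-yl or with furan-3-yl remains open, and so does where a phenyl or pyridine ring would fall at this place. It is also unknown whether the same gap between furan-2-yl and furan-3-yl would appear with a shorter chain leading to the amide-type nitrogen.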